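The compounds below may be only part of what the source reports. "The series", "measured", "known", "first", "only" and "open" are said of these compounds alone.

Compound 1 `N#Cc1c(Nc2cccc(O)c2)sc2ccccc12` and compound 2 `N#Cc1c(Nc2ccccc2)sc2ccccc12` share one core. In a functional assay on HUVEC cells (Homo sapiens), read by fluorescence and microscopy, with a stated time of 6 h, tested at 10 uM (a higher number here means a weaker effect of the compound at the concentration tested, a lower number a stronger effect), compound 1 gives 0% and compound 2 gives 81%, the highest of the two numbers. For the measured compounds named here, the only step in hand is a number 81 percentage points higher from compound 1 to compound 2 (beyond the scatter), a hydroxy giving way to hydrogen. Compound 3 `COc1cccc(Nc2sc3ccccc3c2C#N)c1` differs from compound 2 by methoxy in place of hydrogen on an aromatic carbon. Methoxy is related to hydroxy yet not the same group, so that step bears on this change only loosely. A downward step of uncertain size is therefore expected, a number 26 percentage points lower from compound 2 to compound 3 (beyond the scatter). Compound 3 is estimated at 55%, within 15% to 90%.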

Compound 3, a percentage reported as activity, at one concentration (the size of the read-out at that concentration, not a potency): 81%
Compound 3: the middle estimate sits 26 percentage points below what was measured, within the range that was stated.
By their numbers in this assay, from the lowest: compound 1; then compounds 2 and 3 (each within the scatter of the next).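

Placing methoxy on the aromatic ring, meta to a large group, gives no change at the digits printed from compound 2 to compound 3 (within the scatter) in this assay. Putting methyl on the hydroxy oxygen gives a number 81 percentage points higher from compound 1 to compound 3 (beyond the scatter), so among these three compounds the low number goes with the free hydroxy, and an oxygen at this position is not enough on its own. Nothing available explains this difference. Going by these compounds, whether an amine or a carboxylic acid at the same position would also give a low number remains open.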